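The source may report more compounds than this note shows. Statements on the series, on what has been measured and on what is new or still open speak of the compounds shown alone.

Compound 3 `N=C(NCCCc1c[nH]cn1)NCCC(c1ccc(Br)cc1)c1ccccn1` closes a series of three compounds that share one core and differ only in the group on one aromatic carbon. In a functional assay on muscle tissue for agonist activity at histamine H2 receptor (Cavia porcellus) (a lower number here means a less potent compound, a higher number a more potent compound, by a factor of ten per unit of this negative logarithm), compound 1 `N=C(NCCCc1c[nH]cn1)NCCC(c1ccccc1)c1ccccn1` gives 7.37, compound 2 `N=C(NCCCc1c[nH]cn1)NCCC(c1ccc(F)cc1)c1ccccn1` gives 7.94, and compound 3 gives 6.97, the lowest of the three: the steps to the others, a number 0.40 log units lower from compound 1 to compound 3 (beyond the scatter) and a number 0.97 log units lower from compound 2 to compound 3 (beyond the scatter), are both beyond the scatter, so compound 3 is the least potent compound measured.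

Compound 4 `N=C(NCCCc1c[nH]cn1)NCCC(c1ccc(C(F)(F)F)cc1)c1ccccn1` carries the change (trifluoromethyl in place of bromo on an aromatic carbon), placed para to a large group. Among the compounds with values here, two measured steps bear on it. Putting bromo in place of hydrogen gave a number 0.40 log units lower from compound 1 to compound 3 (beyond the scatter); putting bromo in place of fluoro gave a number 0.97 log units lower from compound 2 to compound 3 (beyond the scatter). Fluoro is thus the best group seen here and bromo the worst, with the unsubstituted compound between them. Within the data shown here, no measured step shows trifluoromethyl, so the step from compound 3 is expected to stay within the scatter, a number 0.03 log units higher from compound 3 to compound 4 (within the scatter). Compound 4 is estimated at 7 in this assay, with a likely range of 6.4 to 7.6.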

Compound 4, negative logarithm of the half-maximal effective concentration: 7.23
The estimate for compound 4 lay 0.23 log units below the measured number; the range from low to high includes it.
By their numbers in this assay, from the lowest: compounds 3, 4 and 1 (each within the scatter of the next, the first and the last beyond it); then compound 2.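

In this assay trifluoromethyl on this aromatic carbon, para to a large group, gives the first result that cannot be told apart from the unsubstituted compound, with a number 0.14 log units lower from compound 1 to compound 4 (within the scatter) and also a number 0.26 log units higher from compound 3 to compound 4 (within the scatter) against bromo. Fluoro alone now stands clear of every other compound in the series, since trifluoromethyl in its place gives a number 0.71 log units lower from compound 2 to compound 4 (beyond the scatter) and the four heavy atoms of trifluoromethyl and the single atom of bromo give results within the scatter of each other. Nothing available here accounts for the standing of fluoro.

From the compounds shown here alone, whether a chloro, methoxy or amine group on this carbon would fall with fluoro or with the other compounds stays open. Going by these compounds, it is also open whether fluoro would hold its standing on another carbon of that ring.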